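The compounds below may be only part of what the source reports. "The series", "measured", "known", "first", "only" and "open" are said of these compounds alone.

Measured in a functional assay on cells (Homo sapiens) for cytotoxicity, read by MTT assay, with a stated time of 24 h; on this read-out higher numbers stand for weaker inhibition and lower numbers for stronger inhibition:

Compound 1 `CCCCCCCCCCCCCCNC(=O)[C@H](CO)/N=C/c1cccc(OC)c1`: 31300 nM
Compound 2 `CCCCCCCCCCCCCCNC(=O)[C@H](CO)/N=C/c1ccc(O)cc1`: 19300 nM

With only these two values available, compound 2 cannot be ranked ahead of compound 1, since the two lie within the scatter of each other. Compound 3 `CCCCCCCCCCCCCCNC(=O)[C@H](CO)/N=C/c1ccc([N+](=O)[O-])cc1` keeps the core of compound 2 and differs from it in one place: nitro in place of hydroxy on an aromatic carbon. This puts nitro in place of hydroxy on an aromatic carbon, para to a large group, turning 4-hydroxyphenyl into 4-nitrophenyl.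

Going by the values given here, only one measured step bears on this change: a 1.6-fold lower number from compound 1 to compound 2 (0.21 log units; within the scatter). It replaced 3-methoxyphenyl with 4-hydroxyphenyl at the same aromatic ring and stayed within the scatter. Among the compounds with values here, no measured compound carries a nitro group, so this is thin guidance, and it gives no direction. No step beyond the scatter is therefore expected in this assay. The estimated step, a 1.1-fold higher number from compound 2 to compound 3 (0.06 log units; within the scatter), is expected to be small. Compound 3 is expected at 22000 nM, with an estimated range of 9000 nM to 50000 nM.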

Compound 3, half-maximal inhibitory concentration: 217000 nM
Beside the measured number, compound 3's estimate is 9.9-fold (0.99 log units) below it; the whole stated range lies below it.
By their numbers in this assay, from the lowest: compounds 2 and 1 (each within the scatter of the next); then compound 3.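

In this assay the substituent on the aromatic ring proves able to move the number well beyond the scatter, which the earlier pair, with its step of a 1.6-fold lower number from compound 1 to compound 2 (0.21 log units; within the scatter), did not show. Nitro in place of hydroxy, on the aromatic carbon para to a large group, gives an 11-fold higher number from compound 2 to compound 3 (1.05 log units; beyond the scatter) and so means clearly weaker inhibition, while the comparison with the 3-methoxyphenyl compound points the same way, with a 6.9-fold higher number from compound 1 to compound 3 (0.84 log units; beyond the scatter) in the change to 4-nitrophenyl. Compound 3 therefore stands as the weakest of the three on this read-out, and 4-hydroxyphenyl and 3-methoxyphenyl remain within the scatter of each other, so the loss is tied to the 4-nitrophenyl compound alone, and no measurement at hand says why the number rises so far.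

With one nitro compound in the series, the compounds shown leave open whether the large rise belongs to nitro specifically or would also appear with another group at the same place, such as an amine, a nitrile or a carboxylic acid. They also leave open whether a step of this size would hold with a shorter chain on the amide nitrogen in place of the long chain shared by all three compounds.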